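The source may report more compounds than this note shows. Statements on the series, on what has been measured and on what is new or still open speak of the compounds shown alone.

Measured compounds in an ADME assay on HUVEC cells (Homo sapiens) for antiproliferative activity, read by MTT assay, with a stated time of 48 h; on this read-out higher numbers stand for weaker inhibition and lower numbers for stronger inhibition:

compound 1 `CC(=O)Nc1ccc(-n2nncc2CN2C(=O)C3(C(C#N)=C(N)Oc4c3c3nc5ccccc5nc3c3ccccc43)c3ccccc32)cc1` gives > 50000 nM, a limit of the assay
compound 2 `Cc1ccc(-n2nncc2CN2C(=O)C3(C(C#N)=C(N)Oc4c3c3nc5ccccc5nc3c3ccccc43)c3ccccc32)cc1C` gives > 50000 nM, a limit of the assay
compound 3 `N#CC1=C(N)Oc2c(N)cc3nc4ccccc4nc3c2C12C(=O)N(Cc1cnnn1-c1ccccc1Br)c1ccccc12` gives 34200 nM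

Compound 3 is the only one of the three with a number in this assay; the other two results sit at the limit of > 50000 nM in this assay, at which 2 of the 3 values shown sit. Within the data shown here, the one structural step with two measured ends, a step that the two limits leave unreadable from compound 1 to compound 2, runs between two limits and gives no size. Among the measured compounds shown here, compound 3 therefore stands alone, and nothing measured so far places it above or below the others.

Compound 4 `N#CC1=C(N)Oc2c(N)cc3nc4ccccc4nc3c2C12C(=O)N(Cc1cnnn1-c1cc(Cl)ccc1Cl)c1ccccc12` is unmeasured. It differs from compound 3 only in 2,5-dichlorophenyl in place of 2-bromophenyl on an aromatic nitrogen. For the measured compounds named here, no measured step touches the group on this aromatic nitrogen with both ends as numbers, so no direction or size can be read from the data for this assay. With nothing to point either way, the step of a 1.0-fold higher number from compound 3 to compound 4 (0.01 log units; within the scatter) is expected to stay within the usual scatter. Compound 4 is accordingly estimated at 35000 nM in this assay, with a range from 15000 nM to 80000 nM; a result reported only as a limit, as for compound 1 and compound 2, is a real possibility.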

Compound 4, half-maximal inhibitory concentration: > 50000 nM
Compound 4: a limit, no number; the forecaster's own chance of this, stated with the estimate: 40%; at least 1.4-fold (0.15 log units) between middle value and limit.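

For the group on the aromatic nitrogen of the five-membered ring, the series now has its first step with a measured number at one end: in this assay, 2,5-dichlorophenyl in place of 2-bromophenyl gives an at least 1.4-fold higher number from compound 3 to compound 4 (0.16 log units; that floor lies within the scatter). Compound 4 gives a limit, not a number, which leaves the step with a floor but no upper size, and that floor does not separate the two compounds beyond the scatter. The change from one bromine to two chlorines therefore brings no measurable gain in inhibition, and compound 3 remains the only compound with a number, while the other results share one ceiling: the limit of > 50000 nM in this assay, at which 3 of the 4 values shown sit.

The compounds shown do not separate the loss of the bromine from the entry of the two chlorines, nor do they show which of the two chlorines matters for the result. On these data alone, whether a 2-chlorophenyl, or a phenyl carrying an amine or a carboxylic acid, on this nitrogen would give a number in this read-out, and on which side of compound 3 it would fall, stays open.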